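Z-Stilbene Core: Methyl to Ethyl, Expected Effect

The source may report more compounds than this note shows. Statements on the series, on what has been measured and on what is new or still open speak of the compounds shown alone.

Measured so far:
- compound 1, `Cc1nc2c(OCc3ccccc3)nccn2c1N`, gives 70% in a functional assay on the whole organism (stomach) for inhibition, with Canis familiaris (Canis lupus familiaris) as the target, at a dose of 8 mg/kg by the oral route; on this read-out lower numbers stand for a weaker effect and higher numbers for a stronger effect at the one dose given.
- compound 2, `Cc1nc2c(/C=C\c3ccccc3)cccn2c1C`, gives 74% in this assay.
- compound 3, `Cc1nc2c(/C=C/c3ccccc3)cccn2c1C`, gives 3% in this assay.

Compound 2 holds the highest number of the three in this assay, though compound 1 sits within the scatter of it, so no order between those two can be read. Compound 3 lies far apart: the step of a number 71 percentage points lower from compound 2 to compound 3 (beyond the scatter) is large, and it is attributable to the configuration of the drawn double bond because of the fact that compounds 2 and 3 differ only in the configuration as drawn.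

The unmeasured compound 4, `CCc1c(C)nc2c(/C=C\c3ccccc3)cccn12`, departs from compound 2 by methyl in place of hydrogen on a saturated chain carbon bound to an aromatic carbon. Within the data shown here, none of the measured steps touches such a change: the one step available concerns only the double-bond configuration, which compound 4 keeps as drawn in compound 2. The expectation for compound 4 in this assay therefore rests on compound 2 alone, with no step beyond the scatter foreseen. Compound 4 is estimated at 70%, between 50% and 88%, a step of a number 4 percentage points lower from compound 2 to compound 4 (within the scatter) that is expected to stay within the scatter.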

Compound 4, a percentage reported as inhibition, in the whole organism at one dose (the size of the read-out at that dose, not a potency): 21%
The estimate for compound 4 lay 49 percentage points above the measured number; the whole stated range lies above it.
By their numbers in this assay, from the lowest: compound 3; then compound 4; then compounds 1 and 2 (each within the scatter of the next).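

In this assay, methyl in place of hydrogen on a saturated chain carbon bound to an aromatic carbon, which reads as methyl to ethyl, gives a number 53 percentage points lower from compound 2 to compound 4 (beyond the scatter), with the Z double bond kept as drawn. The earlier compounds shown here showed a large effect of the double-bond configuration only, whereas this step shows that the read-out also responds strongly at this position, to a change of a single carbon. Nothing in the data shown gives a reason for this loss.

On these data alone, what stays open is whether a longer chain such as propyl, or an amine or a hydroxyl on this carbon, would lower the number further or bring it back. As far as these compounds go, it is equally open whether methyl to ethyl would have a similar effect with the E double bond of compound 3.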